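Hydroxy for cyclopropyl on the 4-ethoxyphenyl compound

A few compounds are considered here, and "the series" means these few. Any claim that something is new, unique, unknown or untested is made for them only; others in the source may bear on it.

Measured so far:
- compound 1 `COc1ccc(C2C(O)C(=O)N2c2cc(OC)c(OC)c(OC)c2)cc1`: 12 nM
- compound 2 `CCOc1ccc(C2C(C3CC3)C(=O)N2c2cc(OC)c(OC)c(OC)c2)cc1`: 63 nM

In a functional assay on HT-29 cells (Homo sapiens) for inhibition, read by sulforhodamine B assay, with a stated time of 72 h (on this read-out lower numbers stand for stronger inhibition and higher numbers for weaker inhibition), compound 2 stands at 63 nM, the higher number of the two, and its gap to compound 1 lies beyond the scatter. The two compounds differ in more than one place, so that gap cannot be assigned to either difference.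

The next compound is compound 3 `CCOc1ccc(C2C(O)C(=O)N2c2cc(OC)c(OC)c(OC)c2)cc1`, not yet measured, in which hydroxy replaces cyclopropyl on a saturated ring carbon: hydroxy in place of cyclopropyl on a saturated ring carbon. The 4-ethoxyphenyl group stays as it is in compound 2.

For the measured compounds named here, no measured pair isolates this change. Going by the values given here, the only guide is compound 1, which carries hydroxy on that ring carbon and reads 12 nM, though it lacks the 4-ethoxyphenyl group. On that single comparison, a move to a lower number in this assay, beyond the scatter, is expected. The expected size is a 3.2-fold lower number from compound 2 to compound 3 (0.50 log units; beyond the scatter).

For compound 3 the estimated value is 20 nM, with an expected range of 6 nM to 70 nM.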

Compound 3, half-maximal inhibitory concentration: 15 nM
For compound 3 the middle estimate is 1.3-fold (0.12 log units) above the measured one; the range from low to high includes it.
By their numbers in this assay, from the lowest: compounds 1 and 3 (each within the scatter of the next); then compound 2.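

In this assay, for the compounds shown here, the step of a 4.2-fold lower number from compound 2 to compound 3 (0.62 log units; beyond the scatter) is the first reading on this saturated ring carbon with the 4-ethoxyphenyl group held constant, and it favours hydroxy over cyclopropyl by more than the scatter. The second step, a 1.3-fold higher number from compound 1 to compound 3 (0.10 log units; within the scatter), isolates the methyl added to the aryl ether with hydroxy held on the ring carbon, and it stays within the scatter, so this one pair shows no measurable difference between the two ethers. Nothing available accounts for either step.

The change removes a three-membered carbon ring and brings in a single oxygen with one hydrogen-bond donor and one hydrogen-bond acceptor, so this pair cannot separate the loss of the ring from the gain of the hydroxy group; an amine, a methyl or a methoxy on the same ring carbon would bear on that question. How far the ether can grow also remains open, since a longer chain such as propoxy or butoxy on the aromatic ring lies outside the compounds shown.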